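This account rests on a few compounds, and the source may have more. Where it says the series, first, only, none or still open, it means among the compounds named here.

Of the compounds shown here, three with a shared core have been measured in a functional assay on MCF7 cells (Homo sapiens) for antiproliferative activity, read by MTT assay, with a stated time of 48 h; a higher number here means a weaker inhibitor, a lower number a stronger inhibitor. Compound 3 `COc1ccc(F)cc1C1=C(c2ccccc2)C2(C=CC(=O)C=C2)OC1=O` gives 5730 nM in this assay. Compound 1 `O=C1C=CC2(C=C1)OC(=O)C(c1cc3ccccc3o1)=C2c1ccccc1` gives 5800 nM, and compound 2 `O=C1C=CC2(C=C1)OC(=O)C(c1ccc([N+](=O)[O-])cc1)=C2c1ccccc1` gives 5990 nM. Compound 3 sits alongside both: the step of a 1.0-fold lower number from compound 1 to compound 3 (0.01 log units; within the scatter) and the step of a 1.0-fold lower number from compound 2 to compound 3 (0.02 log units; within the scatter) lie within the scatter, as does the step of a 1.0-fold higher number from compound 1 to compound 2 (0.01 log units; within the scatter), so the three numbers cannot be told apart.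

Compound 4 `O=C1C=CC2(C=C1)OC(=O)C=C2c1ccccc1` has not yet been measured in this assay. It differs from compound 3 by hydrogen in place of 5-fluoro-2-methoxyphenyl on a double-bonded ring carbon.

The three measured steps each exchange one aromatic group for another on that same double-bonded ring carbon, and none of them moved the number beyond the scatter. Among the measured compounds shown here, no measured step removes the aromatic group altogether and leaves a hydrogen, so the data bear on the change to compound 4 only indirectly. Given that the exchanges among compounds 1, 2 and 3 all left the number essentially unchanged, the step from compound 3 to compound 4 is expected to be a 1.3-fold higher number from compound 3 to compound 4 (0.12 log units; within the scatter), with wide uncertainty because the removal is a larger change than any tested. The value of compound 4 is estimated at 7500 nM, with a range from 2500 nM to 30000 nM.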

Compound 4, half-maximal inhibitory concentration: 6460 nM
Estimate against measurement, compound 4: 1.2-fold (0.06 log units) above, and the stated range covers the measured number.
By their numbers in this assay, from the lowest: compounds 3, 1, 2 and 4 (each within the scatter of the next).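

Taking the aromatic group off the double-bonded ring carbon altogether, a change no earlier pair had tested, gave a 1.1-fold higher number from compound 3 to compound 4 (0.05 log units; within the scatter) in this assay and likewise a 1.1-fold higher number from compound 2 to compound 4 (0.03 log units; within the scatter) and a 1.1-fold higher number from compound 1 to compound 4 (0.05 log units; within the scatter) with all three steps within the scatter. At this position, then, a bare hydrogen cannot be told apart from 5-fluoro-2-methoxyphenyl, 4-nitrophenyl or 1-benzofuran-2-yl, so among these four compounds no aromatic group on this carbon is shown to be needed for the measured antiproliferative number. Nothing is available that would explain why the number stays put across these changes.

The compounds shown leave open whether any group on this carbon can move the number at all, as only hydrogen and aromatic groups stand there so far, and an amine, a carboxylic acid or a longer alkyl chain would be a different kind of test. They also leave open what the phenyl group on the other double-bonded ring atom and the rest of the shared core contribute, as all four compounds keep both unchanged.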